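Anilinoquinazoline series: cytotoxicity on colon carcinoma cells

The source may hold more compounds than are shown below. What is called first, only, known or untested is meant among the compounds shown, and "the series" means these compounds.

Measured so far:
compound 1, `CCS(=O)(=O)Nc1cc(-c2ccc3ncnc(Nc4ccc(OC)c(OC)c4)c3c2)cnc1OC`: in a functional assay on HCT-116 cells (Homo sapiens) for cytotoxicity, read by sulforhodamine B assay, with a stated time of 72 h (on this read-out lower numbers stand for stronger inhibition and higher numbers for weaker inhibition), compound 1 gives 4360 nM
compound 2, `CCCCS(=O)(=O)Nc1cc(-c2ccc3ncnc(Nc4cccc(C(=O)OCC)c4)c3c2)cnc1OC`: in this assay compound 2 gives 26700 nM

Compound 1 holds the lowest of the two numbers; the number of compound 2 lies above it, beyond the scatter. The two differ in more than one place, so their gap cannot be tied to any single change.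

Compound 3, `CCS(=O)(=O)Nc1cc(-c2ccc3ncnc(Nc4ccc(OC)nc4)c3c2)cnc1OC`, is not yet measured. It differs from compound 1 in one place: 6-methoxypyridin-3-yl in place of 3,4-dimethoxyphenyl on a nitrogen on an aromatic ring. Among the compounds with values here, no pair of measured compounds differs in a single place, so there is no measured step of this kind to lean on. The change keeps the amino link to the shared core and exchanges one ring for a closely related one, so the expected step from compound 1 to compound 3 is a 1.4-fold higher number from compound 1 to compound 3 (0.14 log units; within the scatter), small and, if anything, upward, hardly beyond the scatter. Compound 3 is therefore estimated at 6000 nM, with a range from 2000 nM to 18000 nM.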

Compound 3, half-maximal inhibitory concentration: 6910 nM
Estimate against measurement, compound 3: 1.2-fold (0.06 log units) below, within the range that was stated.
By their numbers in this assay, from the lowest: compounds 1 and 3 (each within the scatter of the next); then compound 2.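

First single-place comparison in the series: in this assay, 6-methoxypyridin-3-yl in place of 3,4-dimethoxyphenyl on a nitrogen on an aromatic ring gives a 1.6-fold higher number from compound 1 to compound 3 (0.20 log units; within the scatter). At this position, the two rings therefore cannot be told apart on this read-out, so this exchange, which also brings a ring nitrogen into the substituent, has no effect that can be resolved here. No measurement at hand accounts for this result.

From the compounds shown here alone, whether an amine or a carboxylic acid on this ring would move the number beyond the scatter remains open. Within the data shown here, the separate contribution of each difference between compound 1 and compound 2 also remains unresolved, since no single-place step connects them.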